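Bromine for Chlorine, Tried on a Second Core

The source may report more compounds than this note shows. Statements on the series, on what has been measured and on what is new or still open speak of the compounds shown alone.

Compound 1, with structure `COc1cc(/C=C2\CN(C)C/C(=C\c3ccc(Cl)cc3)C2=O)cc(OC)c1`, gives 11200 nM in a functional assay on HeLa cells (Homo sapiens) for cytotoxicity, read by MTT assay, with a stated time of 24 h; on this read-out lower numbers stand for stronger inhibition and higher numbers for weaker inhibition.
Compound 2, with structure `COc1cc(/C=C2\CN(C)C/C(=C\c3ccc(Br)cc3)C2=O)cc(OC)c1`, gives 5900 nM in this assay.
Compound 3, with structure `CN1C/C(=C\c2ccc(Cl)cc2)C(=O)/C(=C/c2ccc(C#N)cc2)C1`, gives 11200 nM in this assay.

Compounds 1 and 2 share one core and differ only in a single halogen: bromo in place of chloro on an aromatic carbon. This change gave a 1.9-fold lower number from compound 1 to compound 2 (0.28 log units; within the scatter), a step that does not stand out from the noise of repeated testing.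

Compound 3 carries a different core; how the two cores differ is not broken down here. Its value in this assay sits level with that of compound 1, and both values sit close to that of compound 2, so none of the three can be called stronger or weaker than the others.

Compound 4, with structure `CN1C/C(=C\c2ccc(Br)cc2)C(=O)/C(=C/c2ccc(C#N)cc2)C1`, has not yet been tested. It relates to compound 3 exactly as compound 2 relates to compound 1: bromo in place of chloro on an aromatic carbon. The two place descriptions read the same word for word, so this is the same change made on a second core.

Within the data shown here, the only guide is the earlier pair. Since that swap on compound 1 and compound 2 produced a 1.9-fold lower number from compound 1 to compound 2 (0.28 log units; within the scatter), a step of about that size is expected here as well: a 1.6-fold lower number from compound 3 to compound 4 (0.20 log units; within the scatter). The estimate for compound 4 in this assay is therefore 7000 nM, with a plausible range from 3500 nM to 14000 nM.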

Compound 4, half-maximal inhibitory concentration: 5900 nM
For compound 4 the middle estimate is 1.2-fold (0.07 log units) above the measured one; low and high end bracket the measured number.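

Putting bromo in place of chloro on the second core gives a 1.9-fold lower number from compound 3 to compound 4 (0.28 log units; within the scatter) in this assay. Set beside the same swap on the first core, the two steps agree: the same change on two cores in this assay, a 1.9-fold lower number (0.28 log units; within the scatter) from compound 1 to compound 2 and a 1.9-fold lower number (0.28 log units; within the scatter) from compound 3 to compound 4, 1.0-fold (0.00 log units) apart, within the scatter of two such steps

In these two pairs, then, the swap reads the same on both cores, which is what a change that carries over from one core to another would look like, but each step lies within the usual scatter of repeated measurements. The pairs therefore do not show that bromo and chloro truly differ in this series, and two cores cannot say how the swap would read on any further core.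

The compounds shown carry only chloro or bromo at this place, so it remains open how a fluoro group, a methyl group, an amine or a carboxylic acid there would read in this assay, and whether any of these would give a step clearly larger than the scatter. All the numbers also come from one cell type and one read-out, which leaves open whether the agreement between the two cores would hold in other cells.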